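Halogen swap on the amide aryl ring of compound 2

The compounds below may be only part of what the source reports. "The series", "measured", "known", "first", "only" and "open" are said of these compounds alone.

Compound 1 `CC(C)OC(=O)C1CN(C(=O)c2ccc(C#N)cc2)CC(C)(C)c2cc(C#N)[nH]c21`: 91% in an assay on HEK293 cells for agonist activity at Bile acid receptor (Homo sapiens), read by a luciferase reporter; a higher number here means a larger maximal response, a lower number a smaller maximal response
Compound 2 `CC(C)OC(=O)C1=CN(C(=O)c2ccc(F)cc2)CC(C)(C)c2cc(C#N)[nH]c21`: 119% in this assay
Compound 3 `CC(C)OC(=O)C1CN(C(=O)c2ccc(Cl)cc2)CC(C)(C)c2cc(C#N)[nH]c21`: 115% in this assay

Compound 2 gives the highest of the three numbers in this assay; compound 3 sits within the scatter of it, while compound 1 lies beyond the scatter below it. Compound 4 `CC(C)OC(=O)C1=CN(C(=O)c2cccc(Cl)c2)CC(C)(C)c2cc(C#N)[nH]c21` differs from compound 2 by 3-chlorophenyl in place of 4-fluorophenyl on a carbonyl carbon. Among the compounds with values here, the only measured step, a number 24 percentage points higher from compound 1 to compound 3 (beyond the scatter), concerns a different exchange on the same ring and a core without the ring double bond, so it bears only loosely here; it suggests that such exchanges move the maximal response modestly at most. A step of about a number 7 percentage points lower from compound 2 to compound 4 (within the scatter) is therefore expected, within the scatter. Compound 4 is estimated at 112%, between 92% and 132%.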

Compound 4, largest response reached (reported as efficacy), in percent of the reference or control that the assay uses: 122%
Estimate against measurement, compound 4: 10 percentage points below; measured number inside the range.
By their numbers in this assay, from the lowest: compound 1; then compounds 3, 2 and 4 (each within the scatter of the next).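

In this assay, putting 3-chlorophenyl in place of 4-fluorophenyl on the carbonyl carbon gives a number 3 percentage points higher from compound 2 to compound 4 (within the scatter), so the maximal response holds up when this aryl group is exchanged on the core with the ring double bond. This single step alters both the halogen and its place on the ring, and the two alterations cannot be told apart here. Nothing available explains why the response holds. Still open, from the compounds shown here alone, is whether an amine or a carboxylic acid on this phenyl ring, or a cyclohexyl group replacing it, would keep the response.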